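The source may report more compounds than this note shows. Statements on the series, on what has been measured and on what is new or still open speak of the compounds shown alone.

Values so far in an in vitro ADME assay on microsomes from liver (Mus musculus) for metabolic stability; a lower number here means slower removal, a higher number faster removal of the compound

- compound 1 `COCCc1nc2nc(C)cc(Nc3ccc(S(F)(F)(F)(F)F)cc3)n2n1` gives 14.1 mL.min-1.g-1
- compound 2 `Cc1cc(Nc2ccc(S(F)(F)(F)(F)F)cc2)n2nc(C(F)(F)F)nc2n1` gives < 6 mL.min-1.g-1 which is a limit of the assay and not a number
- compound 3 `CSc1nc2nc(C)cc(Nc3ccc(S(F)(F)(F)(F)F)cc3)n2n1` gives 108 mL.min-1.g-1

The lower of the two true numbers belongs to compound 1. Going by the values given here, the change to compound 4 `COCCc1nc2nc(C)cc(Nc3ccc(C(F)(F)F)cc3)n2n1` is a group of 4 heavy atoms (1 carbon, 3 fluorine; no ring) in place of a group of 6 heavy atoms (5 fluorine, 1 sulfur; no ring), on an aromatic carbon and no measured step touches that place. The steps of an at least 2.3-fold lower number from compound 1 to compound 2 (0.37 log units; beyond the scatter) and a 7.7-fold higher number from compound 1 to compound 3 (0.88 log units; beyond the scatter) and an at least 18-fold higher number from compound 2 to compound 3 (1.25 log units; beyond the scatter) all concern another group on the shared core. They show that this assay can respond strongly to a change there but do not test this swap, so no step beyond the scatter is expected. The expected step is a 1.3-fold lower number from compound 1 to compound 4 (0.11 log units; within the scatter) as an estimate. Compound 4 is estimated at 11 mL.min-1.g-1 with an expected range from 6 mL.min-1.g-1 to 28 mL.min-1.g-1 for this measurement.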

Compound 4, intrinsic clearance in microsomes: 14.3 mL.min-1.g-1
Compound 4: the middle estimate sits 1.3-fold (0.11 log units) below what was measured; the measured number falls inside the stated range.
By their numbers in this assay, from the lowest: compounds 1 and 4 (each within the scatter of the next); then compound 3. At a limit, below all of these: compound 2.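

Going by these compounds alone, this is the first step at this place on the ring, where all earlier steps concerned another group on the shared core. In this assay, trifluoromethyl in place of the group of 5 fluorine and 1 sulfur gives a 1.0-fold higher number from compound 1 to compound 4 (0.01 log units; within the scatter), so the two groups cannot be told apart in this pair. Nothing among the data shown bears on why.

On these data alone, whether an amine, a carboxylic acid or a longer chain at this place would also stay within the scatter remains open. So does whether this swap would behave alike with methylsulfanyl on the core.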